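Swapping the ring amide in a diaryl thiophene series

A few compounds are considered here, and "the series" means these few. Any claim that something is new, unique, unknown or untested is made for them only; others in the source may bear on it.

Measured so far:
- compound 1 `CC(C)(C)NC(=O)c1c(N)sc(-c2ccc(Cl)cc2)c1-c1ccc(Cl)cc1`: 15100 nM
- compound 2 `Nc1sc(-c2ccc(Cl)cc2)c(-c2ccc(Cl)cc2)c1C(=O)NC1CCCC1`: 21200 nM
- compound 3 `CC1CN(C(=O)c2c(N)sc(-c3ccc(Cl)cc3)c2-c2ccc(Cl)cc2)CCN1`: 7210 nM

All three were tested in a functional assay on PC-3 cells (Homo sapiens) for inhibition, read by sulforhodamine B assay, with a stated time of 72 h; on this read-out higher numbers stand for weaker inhibition and lower numbers for stronger inhibition. Compound 1 and compound 2 differ only in the group on the amide-type nitrogen, and the step of a 1.4-fold higher number from compound 1 to compound 2 (0.15 log units; within the scatter) shows no real separation between them. Compound 3 carries a ring amine on the carbonyl carbon instead, and it stands at the lowest number of the three: the steps of a 2.1-fold lower number from compound 1 to compound 3 (0.32 log units; beyond the scatter) and a 2.9-fold lower number from compound 2 to compound 3 (0.47 log units; beyond the scatter) are modest but beyond the scatter.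

Compound 4 `Nc1sc(-c2ccc(Cl)cc2)c(-c2ccc(Cl)cc2)c1C(=O)N1CCOCC1` keeps the shared core and the carbonyl, and changes only the ring on that carbonyl carbon: morpholin-4-yl in place of 3-methylpiperazin-1-yl on a carbonyl carbon. For the measured compounds named here, no measured pair shows what happens when one six-membered ring amine is exchanged for another, so the only bearing evidence is that the ring amine of compound 3 did somewhat better than the two open-chain amides of compound 1 and compound 2. On that basis, the expected change a 1.4-fold higher number from compound 3 to compound 4 (0.14 log units; within the scatter) is small, a step within the scatter or a slight move toward a higher number. Compound 4 is therefore estimated at 10000 nM, with a plausible range from 4000 nM to 25000 nM.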

Compound 4, half-maximal inhibitory concentration: 11700 nM
Estimate against measurement, compound 4: 1.2-fold (0.07 log units) below, within the range that was stated.
By their numbers in this assay, from the lowest: compounds 3, 4, 1 and 2 (each within the scatter of the next, the first and the last beyond it).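

In this assay, placing morpholin-4-yl on the carbonyl carbon instead of 3-methylpiperazin-1-yl gives a 1.6-fold higher number from compound 3 to compound 4 (0.21 log units; within the scatter). This first exchange of one six-membered ring for another therefore produces no real separation, even though the entering ring has 0 hydrogen-bond donors where the leaving ring has 1 and lacks the methyl group. Compound 4 also stays within the scatter of the two compounds with cyclopentylamino and (tert-butyl)amino groups, at a 1.8-fold lower number from compound 2 to compound 4 (0.26 log units; within the scatter) and a 1.3-fold lower number from compound 1 to compound 4 (0.11 log units; within the scatter), so a six-membered ring on the carbonyl carbon does not by itself bring the step beyond the scatter that compound 3 shows against them, and no measurement shown here accounts for these results.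

From the compounds shown here alone, what remains open is whether that small advantage of compound 3 belongs to its ring nitrogen carrying a hydrogen, to its methyl group, or to neither. A plain piperazin-1-yl group would separate the ring nitrogen from the methyl group, and a piperidin-1-yl group, with a ring carbon where morpholin-4-yl has its oxygen, would test whether any second hetero atom in the ring matters at all.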